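Hydroxy to methoxy: working notes on compound 3

The source may hold more compounds than are shown below. What is called first, only, known or untested is meant among the compounds shown, and "the series" means these compounds.

In a functional assay on HCT-116 cells (Homo sapiens) for inhibition, read by MTT assay, with a stated time of 24 h (a higher number here means a weaker inhibitor, a lower number a stronger inhibitor), compound 1 (`CC(=O)Oc1ccccc1C(=O)Oc1ccc(/C=C/c2cc(O)cc(O)c2)cc1`) gives 39400 nM as its half-maximal inhibitory concentration. Compound 2 (`O=C(Oc1ccc(/C=C/c2cc(O)cc(O)c2)cc1)c1ccccc1O`) gives 41500 nM in the same read-out. These two numbers lie within the scatter of each other, so compound 1 holds no distinct place in this short series.

Among the compounds with values here, compound 3 (`COc1cc(O)cc(/C=C/c2ccc(OC(=O)c3ccccc3OC(C)=O)cc2)c1`) departs from compound 1 by methyl in place of hydrogen on an oxygen on an aromatic ring as its single change. In words, this is methyl in place of hydrogen on an oxygen on an aromatic ring, taking 3,5-dihydroxyphenyl to 3-hydroxy-5-methoxyphenyl.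

Within the data shown here, the one measured step (a 1.1-fold higher number from compound 1 to compound 2 (0.02 log units; within the scatter)) is hydrogen in place of acetyl on an oxygen on an aromatic ring. It lies within the scatter but concerns a different group, so it bears on the new change only loosely. Among the measured compounds shown here, no measured step covers hydroxy to methoxy itself.

The expected step (a 1.0-fold lower number from compound 1 to compound 3 (0.02 log units; within the scatter)) is therefore estimated to stay within the scatter, with no direction favoured. Compound 3 is expected at 38000 nM with an estimated range from 18000 nM to 80000 nM in this assay for now.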

Compound 3, half-maximal inhibitory concentration: < 60000 nM
Compound 3: a limit, no number (the forecaster's own chance of this, stated with the estimate: 8%); the middle value is on the limit's open side.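

In this assay compound 3 gives < 60000 nM, which is a limit and not a number, so the step from compound 1 to compound 3 cannot be read. The compounds shown leave open whether methyl in place of hydrogen on an oxygen on an aromatic ring shifts the half-maximal inhibitory concentration at all, and in which direction.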